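This account rests on a few compounds, and the source may have more. Where it says the series, first, only, none or still open, it means among the compounds named here.

Compound 2 `CC(=O)c1ccc(NC(=O)CSC(=S)N[C@H]2CCOC2=O)cc1` carries an acetyl on the aromatic ring of the shared core. In a functional assay on SMMC-7721 cells (Homo sapiens) for cytotoxicity, read by MTT assay, with a stated time of 72 h (a lower number here means a stronger inhibitor, a higher number a weaker inhibitor), compound 2 gives > 128000 nM, which is a limit of the assay rather than a number. Compound 1 `O=C(CSC(=S)N[C@H]1CCOC1=O)Nc1ccc(Cl)cc1`, with chloro in that place, gives > 128000 nM in this assay, again only a limit. Compound 3 `CCCCc1ccc(NC(=O)CSC(=S)N[C@H]2CCOC2=O)cc1`, with butyl there, gives 27300 nM. Compound 2 thus sits at the limit of > 128000 nM in this assay, at which 2 of the 3 values shown sit, and the step that the two limits leave unreadable from compound 1 to compound 2 cannot be read, whereas an at least 4.6-fold lower number from compound 1 to compound 3 (0.67 log units; beyond the scatter) and an at least 4.6-fold lower number from compound 2 to compound 3 (0.67 log units; beyond the scatter) are both readable.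

Compound 4 `O=C(CSC(=S)N[C@H]1CCOC1=O)Nc1ccc(C(=O)/C=C/c2ccc(F)cc2)cc1` differs from compound 2 by 2-(4-fluorophenyl)ethenyl in place of methyl on a carbonyl carbon. Among the measured compounds shown here, the one readable step starting at compound 2, toward compound 3, shows a larger group on that aromatic carbon bringing the number down from the limit; no measured pair matches the present change, so the expectation rests on that single step. Compound 4 is accordingly expected to give an estimated 30000 nM, within 8000 nM to 128000 nM. The step this estimate implies, an at least 4.2-fold lower number from compound 2 to compound 4 (0.63 log units; beyond the scatter), is expected to be at least modest and downward.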

Compound 4, half-maximal inhibitory concentration: > 128000 nM
Compound 4 ended at the assay's limit; the forecaster's own chance of this, stated with the estimate: 30%; middle value at least 4.2-fold (0.63 log units) from the limit.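

In this assay compound 4 gives > 128000 nM, which is a limit of the assay. Compound 2 also stands at a limit, so the step between compound 2 and compound 4 cannot be read. The compounds shown leave open whether 2-(4-fluorophenyl)ethenyl in place of methyl on a carbonyl carbon changes the number at all.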